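A few compounds are considered here, and "the series" means these few. Any claim that something is new, unique, unknown or untested is made for them only; others in the source may bear on it.

In an ADME assay on microsomes from liver (Homo sapiens) for metabolic stability (on this read-out lower numbers stand for a shorter-lived compound and higher numbers for a longer-lived compound), compound 3 `C[C@@H]1CCC[C@H](N2CCC(c3cc(Cl)ccc3-n3ccnn3)=CC2=O)c2cc(ccn2)-c2c(cnn2C)NC1=O` gives 1.13 h. Compound 2 `C[C@@H]1CCC[C@H](N2CCC(c3cc(Cl)ccc3-n3cc(Cl)nn3)=CC2=O)c2cc(ccn2)-c2c(cnn2C)NC1=O` gives 1.08 h and cannot be told apart from it, as the step of a 1.0-fold higher number from compound 2 to compound 3 (0.02 log units; within the scatter) shows. Compound 1 `C[C@@H]1CCC[C@H](N2CCC(c3cc(Cl)ccc3-n3ccnn3)=CC2=O)c2cc(ccn2)-c2c(cnn2C2CCC2)NC1=O` gives 0.1 h, far below both of them. Compound 4 `C[C@@H]1CCC[C@H](N2CCC(c3cc(Cl)ccc3-n3ccnn3)=CC2=O)c2cc(ccn2)-c2c(cnn2C2CC2)NC1=O` has not yet been measured; it differs from compound 3 in a single place: cyclopropyl in place of methyl on an aromatic nitrogen. Going by the values given here, the one measured step that bears on this change is an 11-fold higher number from compound 1 to compound 3 (1.05 log units; beyond the scatter), in which a cyclobutyl ring gave way to methyl on the same kind of aromatic nitrogen. Cyclopropyl is a three-membered ring, smaller than cyclobutyl but larger than methyl, so putting a ring back in this position is expected to move the number downward, though plausibly by less than the whole distance seen between compound 1 and compound 3. For compound 4 a half-life of 0.4 h is therefore estimated, with a likely range from 0.15 h to 1.1 h, which means an expected step of a 2.8-fold lower number from compound 3 to compound 4 (0.45 log units; beyond the scatter).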

Compound 4, half-life: 0.0833 h
Compound 4: middle estimate off by 4.8-fold (0.68 log units), on the high side; the measured number lies below the stated range.
By their numbers in this assay, from the lowest: compounds 4 and 1 (each within the scatter of the next); then compounds 2 and 3 (each within the scatter of the next).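

In this assay the change to cyclopropyl on the aromatic nitrogen gives a 14-fold lower number from compound 3 to compound 4 (1.13 log units; beyond the scatter) and so a ring of only three carbons is enough to lose the longer half-life seen with methyl. Set against cyclobutyl, cyclopropyl gives a 1.2-fold lower number from compound 1 to compound 4 (0.08 log units; within the scatter) and the two rings cannot be told apart, so among these three groups methyl alone stands apart and the number does not follow ring size. Nothing measured here explains why the two rings behave alike.

As far as these compounds go, what an ethyl or isopropyl group on this nitrogen would give stays open, and with it whether the half-life falls step by step or all at once after methyl. Also open, from the compounds shown here alone, is whether a chain holding an ether oxygen, such as methoxyethyl, would follow the rings or methyl.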